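Adding an Ethyl Group on Two Related Cores

The source may report more compounds than this note shows. Statements on the series, on what has been measured and on what is new or still open speak of the compounds shown alone.

In a functional assay for inhibition of sodium/hydrogen exchanger (Oryctolagus cuniculus) (on this read-out higher numbers stand for weaker inhibition and lower numbers for stronger inhibition), compound 2 `CS(=O)(=O)c1cc(C(=O)N=C(N)N)ccc1Br` gives 180 nM. Compound 1 `CCc1cc(Br)c(S(C)(=O)=O)cc1C(=O)N=C(N)N` carries ethyl in place of hydrogen on an aromatic carbon, and this change produced a 4.4-fold lower number from compound 2 to compound 1 (0.64 log units; beyond the scatter). Compound 3 `CS(=O)(=O)c1cc(C(=O)N=C(N)N)ccc1-n1ccc(=O)cc1` differs from compound 2 by a group of 7 heavy atoms (5 carbon, 1 nitrogen, 1 oxygen; one six-membered aromatic ring with 1 hetero atom) in place of one bromine atom, on an aromatic carbon; in this assay compound 3 gives 710 nM, with a 3.9-fold higher number from compound 2 to compound 3 (0.60 log units; beyond the scatter). For comparison, compound 1 gives 41 nM. Compound 4 `CCc1cc(-n2ccc(=O)cc2)c(S(C)(=O)=O)cc1C(=O)N=C(N)N` carries ethyl in place of hydrogen on an aromatic carbon, the same kind of change as from compound 2 to compound 1, though here the ethyl stands meta to a group of 7 heavy atoms rather than meta to a bromo group. With a single earlier example, the step is expected to be of similar size, a 4.4-fold lower number from compound 3 to compound 4 (0.65 log units; beyond the scatter), resting on a 4.4-fold lower number from compound 2 to compound 1 (0.64 log units; beyond the scatter). Compound 4 is therefore expected to give about 160 nM, most likely between 80 nM and 320 nM.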

Compound 4, half-maximal inhibitory concentration: 930 nM
Compound 4: middle estimate off by 5.8-fold (0.76 log units), on the low side, outside the stated range (above it).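

Ethyl in place of hydrogen did not carry over from one core to the other in this assay, where it now gives a 1.3-fold higher number from compound 3 to compound 4 (0.12 log units; within the scatter) and the two steps differ: the same change on two cores in this assay, a 4.4-fold lower number (0.64 log units; beyond the scatter) from compound 2 to compound 1 and a 1.3-fold higher number (0.12 log units; within the scatter) from compound 3 to compound 4, 5.8-fold (0.76 log units) apart, beyond the scatter of two such steps. Read the other way, the group of 7 heavy atoms in place of bromine costs more when the ethyl is present, with a 23-fold higher number from compound 1 to compound 4 (1.36 log units; beyond the scatter) set against the earlier step: the same change on two cores in this assay, a 3.9-fold higher number (0.60 log units; beyond the scatter) from compound 2 to compound 3 and a 23-fold higher number (1.36 log units; beyond the scatter) from compound 1 to compound 4, 5.8-fold (0.76 log units) apart, beyond the scatter of two such steps. This shows that the ethyl step depends on the group that replaces bromine, but with one pair on each core it does not show why, or how general this is.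

On these data alone, it remains open whether a smaller methyl or a longer propyl chain would follow the bromine core or the other one. An amine in place of bromine could also show which of the two behaviours is the more usual.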